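The compounds below may be only part of what the source reports. "The series", "measured", "known", "first", "only" and "open" are said of these compounds alone.

Compound 1 `Cc1cc(Cl)cc(Cl)c1S(=O)(=O)N1CCC(N2CCC(C)CC2)CC1`: 0.6 nM
Compound 2 `CC1CCN(C2CCN(S(=O)(=O)c3nccn3C)CC2)CC1`: > 5000 nM
Compound 3 `COc1cccc(S(=O)(=O)N2CCC(N3CCC(C)CC3)CC2)c1`: > 5000 nM

In a functional assay on DLD-1 cells (Homo sapiens) for antiproliferative activity, read by CellTiter-Glo, with a stated time of 72 h (a higher number here means a weaker inhibitor, a lower number a stronger inhibitor), compound 1 gives 0.6 nM. For compound 2 the value > 5000 nM is a limit of the assay, not a number. For compound 3 the value > 5000 nM is likewise a limit. Compound 3 thus sits at the limit of > 5000 nM in this assay, at which 2 of the 3 values shown sit, together with compound 2 and far from compound 1. Going by the values given here, the one measured step that touches it, a step that the two limits leave unreadable from compound 2 to compound 3, is unreadable, both of its ends being limits.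

Compound 4 `CC1CCN(C2CCN(S(=O)(=O)c3ccc(Cl)cc3Cl)CC2)CC1` differs from compound 3 by 2,4-dichlorophenyl in place of 3-methoxyphenyl on a sulfonyl sulfur. Among the compounds with values here, no measured step covers this change directly; compound 1, which also carries two chlorines on its sulfonyl aryl, gives 0.6 nM in this assay. Compound 4 is therefore expected to be a strong inhibitor, estimated at 5 nM with a range of 0.5 nM to 60 nM. The step of an at least 1000-fold lower number from compound 3 to compound 4 (3.00 log units; beyond the scatter) in this assay is expected to be large and toward stronger inhibition.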

Compound 4, half-maximal inhibitory concentration: 1 nM
Compound 4: the middle estimate sits 5.0-fold (0.70 log units) above what was measured, and the stated range covers the measured number.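

On the sulfonyl sulfur, 2,4-dichlorophenyl gives strong inhibition in this assay, whereas 3-methoxyphenyl and 1-methyl-1H-imidazol-2-yl do not, with an at least 5000-fold lower number from compound 3 to compound 4 (3.69 log units; beyond the scatter) and an at least 5000-fold lower number from compound 2 to compound 4 (3.69 log units; beyond the scatter). Both steps start from limits of the assay, not numbers: the limit of > 5000 nM in this assay, at which 2 of the 4 values shown sit.

Hydrogen in place of methyl on an aromatic carbon makes no readable difference, with a 1.7-fold higher number from compound 1 to compound 4 (0.22 log units; within the scatter). The compounds shown leave open whether a single chlorine would suffice, and whether a nitrile or a trifluoromethyl group could stand in place of the chlorines.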